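A Substituent Swap on a Shared Core

The compounds below may be only part of what the source reports. "The series", "measured", "known", "first", "only" and "open" are said of these compounds alone.

Measured so far:
Compound 1 `C/N=C(/NC)Nc1nc(-c2ccc(OC)cc2)c(-c2ccc(OC)cc2)s1`: 970 nM
Compound 2 `COc1ccc(-c2nc(C(=O)N3CCOCC3)sc2-c2ccc(OC)cc2)cc1`, where the assay reports only a limit: < 10 nM

In a functional assay with Oryctolagus cuniculus as the target (a lower number here means a stronger inhibitor, a higher number a weaker inhibitor), compound 1 gives 970 nM, the only plain number shown. The value of compound 2 is a limit of the assay (the limit of < 10 nM in this assay, at which 1 of the 2 values shown sits). Compound 3 `CCOC(=O)/C(C#N)=C/c1nc(-c2ccc(OC)cc2)c(-c2ccc(OC)cc2)s1` differs from compound 1 in one place: a group of 9 heavy atoms (6 carbon, 1 nitrogen, 2 oxygen; no ring) in place of a group of 6 heavy atoms (3 carbon, 3 nitrogen; no ring), on an aromatic carbon. For the measured compounds named here, the single measured step with the same leaving group, an at least 97-fold lower number from compound 1 to compound 2 (1.98 log units; beyond the scatter), was large. The entering group here is different, so a smaller step downward is expected. For compound 3 the estimate is 150 nM, between 20 nM and 1500 nM. That estimate means an expected 6.5-fold lower number from compound 1 to compound 3 (0.81 log units; beyond the scatter).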

Compound 3, half-maximal inhibitory concentration: < 10 nM
Compound 3: no number, only a limit; the forecaster's own chance of this, stated with the estimate: 10%; middle value at least 15-fold (1.17 log units) away from the limit.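

Putting 2-cyano-2-(ethoxycarbonyl)ethenyl on this aromatic carbon gives an at least 97-fold lower number from compound 1 to compound 3 (1.98 log units; beyond the scatter) and so a second large step, now with an entering group that has no ring. A large step at this position therefore does not depend on the ring of (morpholin-4-yl)carbonyl. The value of compound 3 is a limit, not a number: the limit of < 10 nM in this assay, at which 2 of the 3 values shown sit.

The step between compound 2 and compound 3 cannot be read. Still open, from the compounds shown here alone, is whether a carboxylic acid or a short alkyl chain on this carbon would also reach that limit.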